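A few compounds are considered here, and "the series" means these few. Any claim that something is new, unique, unknown or untested is made for them only; others in the source may bear on it.

Four closely related compounds are compared here. Compound 1 `CNCC[C@@H]1CCO[C@H](c2ccccc2)O1` is the starting point. In an assay for displacement of a labelled ligand from Sigma non-opioid intracellular receptor 1 (Cavia porcellus), read by scintillation counting (on this read-out higher numbers stand for weaker inhibition and lower numbers for stronger inhibition), compound 1 gives 449 nM. Compound 2 `c1ccc(CNCC[C@@H]2CCO[C@H](c3ccccc3)O2)cc1` carries a single change relative to compound 1: phenyl in place of hydrogen on a saturated chain carbon bound to an amine nitrogen. In this assay compound 2 gives 19 nM, which means a 24-fold lower number from compound 1 to compound 2 (1.37 log units; beyond the scatter). Compound 3 `CNCCC[C@@H]1CCO[C@H](c2ccccc2)O1` differs from compound 1 in the core itself, and that difference is counted as (methylamino)methyl in place of methylamino on a saturated chain carbon, two bonds along the chain from a saturated ring carbon. In this assay compound 3 gives 327 nM, and a 1.4-fold lower number from compound 1 to compound 3 (0.14 log units; within the scatter), so this read-out does not tell the two cores apart.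

Compound 4 `c1ccc(CNCCC[C@@H]2CCO[C@H](c3ccccc3)O2)cc1` has not yet been measured. It stands to compound 3 exactly as compound 2 stands to compound 1, the same change made a second time: phenyl in place of hydrogen on a saturated chain carbon bound to an amine nitrogen. Among these compounds that change occurs twice in all, and both times the place is described in identical words, so it may be called the same change rather than merely the same kind. The repeated change is expected to produce a 22-fold lower number from compound 3 to compound 4 (1.34 log units; beyond the scatter), because the first time it produced a 24-fold lower number from compound 1 to compound 2 (1.37 log units; beyond the scatter). That expectation rests on one earlier pair alone, so it carries the spread of a single comparison. In this assay compound 4 is therefore expected to give about 15 nM, most likely between 6 nM and 40 nM.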

Compound 4, inhibition constant: 164 nM
Compound 4: the middle estimate sits 11-fold (1.04 log units) below what was measured; measured number outside the range, above it.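

In this assay, the same difference, methyl to benzyl, gives a 2.0-fold lower number from compound 3 to compound 4 (0.30 log units; within the scatter), so on the core of compound 3 the two numbers cannot be told apart. The large step seen on the core of compound 1 therefore did not carry over to the core of compound 3, and in this pair of cores the size of the step depends on the core that carries it: the same change on two cores in this assay, a 24-fold lower number (1.37 log units; beyond the scatter) from compound 1 to compound 2 and a 2.0-fold lower number (0.30 log units; within the scatter) from compound 3 to compound 4, 12-fold (1.07 log units) apart, beyond the scatter of two such steps. Among these compounds, this does not show why the two cores behave differently, and with only one pair on each core it says nothing about how the change would behave on any third core, only that a step read on one core was a poor guide to the other here.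

The compounds shown leave open whether the difference between the two cores is specific to benzyl or would also appear with another group in its place, such as phenethyl or cyclohexylmethyl. They also leave open what a longer chain in the core would do to the step, and whether a fluorine or a methoxy group on the phenyl ring of benzyl would alter the picture on either core.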